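A few compounds are considered here, and "the series" means these few. Any claim that something is new, unique, unknown or untested is made for them only; others in the source may bear on it.

In a functional assay on U-937 cells (Homo sapiens) for antiproliferative activity, read by WST assay, with a stated time of 72 h (a lower number here means a stronger inhibitor, a higher number a weaker inhibitor), compound 3 `COc1ccc([C@@H]2CCc3c(OC)cc(OC)cc3O2)cc1` gives 18000 nM, the lowest of the two numbers recorded in this assay. Compound 1 `COc1cc(O)c(-c2coc3cc(O)ccc3c2=O)cc1OC` gives 48000 nM in this assay, a number that sits beyond the scatter above that of compound 3. Compound 2 `CC(C)(O)[C@@H](O)Cc1c(O)cc(O)c2c(=O)c(-c3ccc(O)cc3)coc12` gives only > 100000 nM in this assay. That value is a limit of the assay and not a number, namely (the limit of > 100000 nM in this assay, at which 1 of the 3 values shown sits). Compound 4 `COc1cc(OC)c2c(c1)O[C@H](c1ccc(O)cc1)CC2` has not yet been measured in this assay. It differs from compound 3 by hydrogen in place of methyl on an oxygen on an aromatic ring. For the measured compounds named here, no measured pair isolates this change, so its size is uncertain. Compound 4 is expected to give about 25000 nM in this assay, within a range from 8000 nM to 80000 nM. The step that this estimate means, a 1.4-fold higher number from compound 3 to compound 4 (0.14 log units; within the scatter), is expected to stay within the scatter.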

Compound 4, half-maximal inhibitory concentration: 10000 nM
Beside the measured number, compound 4's estimate is 2.5-fold (0.40 log units) above it; the measured number falls inside the stated range.
By their numbers in this assay, from the lowest: compounds 4 and 3 (each within the scatter of the next); then compound 1. At a limit, above all of these: compound 2.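

For the compounds shown here, the first measured pair to isolate hydrogen in place of methyl on an oxygen on an aromatic ring reads, in this assay, a 1.8-fold lower number from compound 3 to compound 4 (0.26 log units; within the scatter). At this position, then, methoxy to hydroxy does not separate the two compounds in this read-out. Nothing measured here accounts for the step.

Going by these compounds, it remains open whether a longer chain on this oxygen, or an amine in its place, would also stay within the scatter. On these data alone, it also remains open whether the same change at the remaining methoxy groups would give a similar result.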